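A few compounds are considered here, and "the series" means these few. Any claim that something is new, unique, unknown or untested is made for them only; others in the source may bear on it.

Measured so far in an ADME assay on MT2 cells (Homo sapiens) for cytotoxicity, read by MTT assay; on this read-out lower numbers stand for higher toxicity in this test and higher numbers for lower toxicity in this test:
Compound 1 `Fc1cccc(F)c1Cc1cnc(Nc2ccc(-c3ccncc3)c(Cl)c2)o1`: 9300 nM
Compound 3 `Fc1cccc(F)c1Cc1cnc(Nc2ccc(Oc3cccnc3)c(Cl)c2)o1`: 16000 nM
Compound 2 `CSCc1ccc(Nc2ncc(Cc3c(F)cccc3F)o2)cc1` reaches only a limit of this assay, > 100000 nM.

Compound 3 thus holds the higher of the two numbers given in this assay, its nearest neighbour being compound 1, and the step of a 1.7-fold higher number from compound 1 to compound 3 (0.24 log units; within the scatter) stays within the scatter. Compound 4 `Fc1cccc(F)c1Cc1cnc(Nc2ccc(Oc3ccncc3)c(Cl)c2)o1` differs from compound 3 by pyridin-4-yl in place of pyridin-3-yl on an oxygen on an aromatic ring. For the measured compounds named here, the only measured step that bears on it is the one from compound 1 to compound 3, which also swaps pyridin-4-yl against a (pyridin-3-yl)oxy arrangement and stays within the scatter. Compound 4 is therefore expected to move by no more than the scatter, a 1.3-fold lower number from compound 3 to compound 4 (0.12 log units; within the scatter). The estimate for compound 4 is 12000 nM, between 5000 nM and 30000 nM; one of the three values shown sits at the limit of > 100000 nM in this assay, at which 1 of the 3 values shown sits, so a limit cannot be excluded.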

Compound 4, half-maximal cytotoxic concentration: 21000 nM
Compound 4: middle estimate off by 1.8-fold (0.24 log units), on the low side; the measured number falls inside the stated range.
By their numbers in this assay, from the lowest: compounds 1, 3 and 4 (each within the scatter of the next, the first and the last beyond it). At a limit, above all of these: compound 2.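

In this assay, the swap of pyridin-3-yl for pyridin-4-yl on an oxygen on an aromatic ring gives a 1.3-fold higher number from compound 3 to compound 4 (0.12 log units; within the scatter), so at this position the two pyridines are not told apart. For the compounds shown here, the (pyridin-4-yl)oxy group in place of pyridin-4-yl on an aromatic carbon gives a 2.3-fold higher number from compound 1 to compound 4 (0.35 log units; beyond the scatter), the first step at this position beyond the scatter, though a modest one. Nothing given here accounts for this step.

The compounds shown leave open how (pyridin-2-yl)oxy would read at this position. They also leave open what an amine or a methylene in place of the oxygen would do.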